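From Fluoro to Hydroxy on an Aromatic Ring

The source may report more compounds than this note shows. Statements on the series, on what has been measured and on what is new or still open speak of the compounds shown alone.

In a functional assay on HCT-116 cells (Homo sapiens) for antiproliferative activity, read by MTT assay, with a stated time of 48 h (a higher number here means a weaker inhibitor, a lower number a stronger inhibitor), compound 1 `COc1ccc(-c2cncc3[nH]c(=O)n(Cc4cc(OC)c(OC)c(OC)c4)c23)cc1` returns only a limit, > 20000 nM. Compound 3 `COc1ccc(-c2cc3c(cn2)[nH]c(=O)n3-c2cc(OC)c(OC)c(OC)c2)cc1F` gives 910 nM, and compound 2 `COc1ccc(-c2cc3c(cn2)[nH]c(=O)n3-c2cc(OC)c(OC)c(OC)c2)cc1` gives 840 nM, so the two stand together within the scatter, and both have real numbers rather than a limit.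

Compound 4 `COc1ccc(-c2cc3c(cn2)[nH]c(=O)n3-c2cc(OC)c(OC)c(OC)c2)cc1O` differs from compound 3 hydroxy in place of fluoro on an aromatic carbon, turning 3-fluoro-4-methoxyphenyl into 3-hydroxy-4-methoxyphenyl. Among the measured compounds shown here, one measured step bears on this, fluoro in place of hydrogen on an aromatic carbon, which gave a 1.1-fold higher number from compound 2 to compound 3 (0.03 log units; within the scatter). For the measured compounds named here, no measured step tests the hydroxy itself or its hydrogen-bond donor, so the expectation stays loose. Given the size of that step, only a small move in this assay is expected, leaning towards a lower number and perhaps not clearing the scatter. The expected change is a 1.8-fold lower number from compound 3 to compound 4 (0.26 log units; within the scatter). Compound 4 is estimated at 500 nM, with an expected range of 100 nM to 1500 nM.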

Compound 4, half-maximal inhibitory concentration: 340 nM
Beside the measured number, compound 4's estimate is 1.5-fold (0.17 log units) above it; the range from low to high includes it.
By their numbers in this assay, from the lowest: compound 4; then compounds 2 and 3 (each within the scatter of the next). At a limit, above all of these: compound 1.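

In this assay this position, ortho to a methoxy group, proves responsive to the group it carries, which compounds 2 and 3 alone could not show: fluoro for hydrogen gave only a 1.1-fold higher number from compound 2 to compound 3 (0.03 log units; within the scatter), within the scatter. Hydroxy, by contrast, gives a 2.7-fold lower number from compound 3 to compound 4 (0.43 log units; beyond the scatter) and, measured against the hydrogen, a 2.5-fold lower number from compound 2 to compound 4 (0.39 log units; beyond the scatter), so both steps clear the scatter, though only modestly. Nothing at hand bears on why hydroxy, with its hydrogen-bond donor, differs from fluoro here.

The compounds shown leave open whether an amine or a carboxylic acid at this place would keep the lower number. The core of compound 1 returns only a limit, and with > 20000 nM as its entry in this assay nothing shows whether hydroxy would act the same way there.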